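The source may report more compounds than this note shows. Statements on the series, on what has been measured and on what is new or still open speak of the compounds shown alone.

Measured so far in a functional assay on HCT-116 cells (Homo sapiens) for antiproliferative activity, read by MTT assay, with a stated time of 48 h; on this read-out higher numbers stand for weaker inhibition and lower numbers for stronger inhibition:
- compound 1 `COc1ccc(CN(C(=O)CSc2nc3ccccc3s2)c2cc(OC)c(OC)c(OC)c2)cc1C`: 17100 nM
- compound 2 `COc1ccc(CN(C(=O)CSc2nc3ccccc3s2)c2cc(OC)c(OC)c(OC)c2)cc1O`: 182 nM
- compound 3 `COc1ccc(CN(C(=O)CSc2nc3cc(Cl)ccc3s2)c2cc(OC)c(OC)c(OC)c2)cc1O`: 429 nM

Among these three, compound 2 at 182 nM has the lowest number, and both of the others lie beyond the scatter from it. Compound 4 `COc1ccc(CN(C(=O)CSc2nc3ccccc3s2)c2cc(OC)c(OC)c(OC)c2)cc1OC` has not yet been measured in this assay. The change from compound 2 is methyl in place of hydrogen on an oxygen on an aromatic ring, which turns the 3-hydroxy-4-methoxybenzyl into 3,4-dimethoxybenzyl.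

The measured step that bears most directly on this change involves the same hydroxy group, which replaces a methyl: a 94-fold lower number from compound 1 to compound 2 (1.97 log units; beyond the scatter). That step is large. Compound 4 also lacks the hydroxy, although it keeps an oxygen there, so a large part of that step is expected to be lost, but perhaps not all of it. The other measured step, a 2.4-fold higher number from compound 2 to compound 3 (0.37 log units; beyond the scatter), is a modest one for a different change and adds little here.

The expected change is a 16-fold higher number from compound 2 to compound 4 (1.22 log units; beyond the scatter), clearly beyond the scatter. For compound 4 the estimated value is 3000 nM, with an expected range from 600 nM to 15000 nM.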

Compound 4, half-maximal inhibitory concentration: 33900 nM
Estimate against measurement, compound 4: 11-fold (1.05 log units) below, outside the stated range (above it).
By their numbers in this assay, from the lowest: compound 2; then compound 3; then compounds 1 and 4 (each within the scatter of the next).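

In this assay, capping the hydroxy with a methyl gives a 190-fold higher number from compound 2 to compound 4 (2.27 log units; beyond the scatter), so the advantage of compound 2 over compound 1 is not kept when the oxygen stays but its hydrogen is lost. Methoxy and methyl at this place cannot be told apart, since a 2.0-fold higher number from compound 1 to compound 4 (0.30 log units; within the scatter) is the whole of the difference between them, and among these compounds the low numbers belong only to compound 2 and compound 3, which both carry the free hydroxy. Nothing shown here gives a cause for this result.

The compounds leave open whether an amine or a fluorine in place of the hydroxy would keep the low number. They also leave open whether a longer chain on the oxygen, such as ethoxy, would stay with compound 4 or move further still.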